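The source may report more compounds than this note shows. Statements on the series, on what has been measured and on what is new or still open speak of the compounds shown alone.

In a functional assay on HT-29 cells (Homo sapiens) for cytotoxicity, read by MTT assay, with a stated time of 72 h (a lower number here means a stronger inhibitor of growth, a higher number a weaker inhibitor of growth), compound 1 `Cc1ccc(/C=C(/C#N)C(=O)c2ccc[nH]2)cc1` gives 14000 nM, the lower of the two true numbers in the series. Compound 2 `N#C/C(=C/c1ccc(Cl)cc1)C(=O)c1ccc[nH]1` gives 54000 nM. Compound 3 `N#C/C(=C/c1ccc(O)cc1)C(=O)c1ccc[nH]1` is reported only as a limit, < 10000 nM.

Compound 4 `COc1ccc(/C=C(/C#N)C(=O)c2ccc[nH]2)cc1` carries methoxy in place of methyl on an aromatic carbon, para to a large group. Among the measured compounds shown here, two measured steps bear on this place. Chloro in place of methyl gave a 3.9-fold higher number from compound 1 to compound 2 (0.59 log units; beyond the scatter). Hydroxy in place of methyl gave an at least 1.4-fold lower number from compound 1 to compound 3 (0.14 log units; that floor lies within the scatter). With these two steps not agreeing in direction, no step beyond the scatter is expected in this assay. The expected step is a 1.2-fold lower number from compound 1 to compound 4 (0.07 log units; within the scatter). For compound 4 the estimated value is 12000 nM, with an expected range of 4000 nM to 40000 nM.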

Compound 4, concentration for 50% growth inhibition: < 10000 nM
Compound 4: a limit, no number; the forecaster's own chance of this, stated with the estimate: 30%; middle value at least 1.2-fold (0.07 log units) away from the limit.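

In this assay compound 4 is reported only as a limit, < 10000 nM. Methoxy in place of chloro gives an at least 5.4-fold lower number from compound 2 to compound 4 (0.73 log units; beyond the scatter), so a second oxygen-linked group separates from chloro, while methoxy in place of methyl gives an at least 1.4-fold lower number from compound 1 to compound 4 (0.14 log units; that floor lies within the scatter). The step between hydroxy and methoxy cannot be read, as compound 3 and compound 4 share one limit: the limit of < 10000 nM in this assay, at which 2 of the 4 values shown sit.

True numbers for compound 3 and compound 4 are still needed to settle whether either differs from methyl. From the compounds shown here alone, how an amine or a carboxylic acid would read at this place also stays open.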